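A Fluorine Step Repeated on a Second Core

This account rests on a few compounds, and the source may have more. Where it says the series, first, only, none or still open, it means among the compounds named here.

In an assay on U2OS cells for activation of nuclear factor erythroid 2-related factor 2 (Homo sapiens), read by chemiluminescence, with a stated time of 6 h (on this read-out higher numbers stand for an effect only at larger amounts of compound and lower numbers for an effect already at smaller amounts), compound 1 `COc1ccccc1S(=O)(=O)/C=C/c1ccccn1` gives 9070 nM. Compound 2 `COc1ccccc1S(=O)(=O)/C=C/c1ncccc1F` differs from compound 1 by fluoro in place of hydrogen on an aromatic carbon, and in this assay compound 2 gives 877 nM. The result is a 10-fold lower number from compound 1 to compound 2 (1.01 log units; beyond the scatter).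

Compound 3 `COc1ccc(S(=O)(=O)/C=C/c2cccnc2)cc1` is built from the same atoms as compound 1, joined differently; the difference between the two cores is not broken down here. For compound 3 this assay returns only a limit, > 10000 nM.

Compound 4 `COc1ccc(S(=O)(=O)/C=C/c2ccc(F)nc2)cc1` has not yet been measured. It differs from compound 3 by fluoro in place of hydrogen on an aromatic carbon. Among the measured compounds shown here, this is the same kind of change as the one from compound 1 to compound 2, but not the same: in compound 2 the fluoro sits ortho to a large group and two atoms from the ring nitrogen, whereas in compound 4 it sits next to the ring nitrogen and para to a large group.

Compound 3 offers only a limit as a starting point, so any estimate for compound 4 carries wide bounds. Resting on a 10-fold lower number from compound 1 to compound 2 (1.01 log units; beyond the scatter) but tempered by the different place of the fluoro, the expected step is an at least 1.6-fold lower number from compound 3 to compound 4 (0.22 log units; that floor lies within the scatter). Compound 4 is therefore estimated at 6000 nM in this assay, most likely between 1500 nM and 30000 nM, with a real chance that this assay again returns only a limit.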

Compound 4, half-maximal effective concentration: 6850 nM
Estimate against measurement, compound 4: 1.1-fold (0.06 log units) below; low and high end bracket the measured number.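

In this assay, fluoro in place of hydrogen on an aromatic carbon gives an at least 1.4-fold lower number from compound 3 to compound 4 (0.16 log units; that floor lies within the scatter), which points the same way as a 10-fold lower number from compound 1 to compound 2 (1.01 log units; beyond the scatter), although the floor of the new step does not by itself go beyond the usual scatter. The change therefore does not carry over as a measured repeat, and in compound 4 the fluoro also stands in another place, next to the ring nitrogen and para to a large group, so the comparison of the two cores stays loose: the same change on two cores in this assay, a 10-fold lower number (1.01 log units; beyond the scatter) from compound 1 to compound 2 and an at least 1.4-fold lower number (0.16 log units; that floor lies within the scatter) from compound 3 to compound 4; the limit leaves it open whether they differ. What remains unshown is the true size of the step on the second core, since its starting point, compound 3, has only a limit of the assay: the limit of > 10000 nM in this assay, at which 1 of the 4 values shown sits.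

The compounds shown leave open whether chloro, a nitrile or an amine in the place of the fluoro would move the number on either core, and whether a carboxylic acid there would do the same. They also leave open how the fluoro would behave at other places on the ring of compound 3, so the effect of place and the effect of core cannot yet be told apart.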